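A few compounds are considered here, and "the series" means these few. Any claim that something is new, unique, unknown or untested is made for them only; others in the source may bear on it.

Working notes on the amide series built on a shared core. Compound 1 `COc1cc2nccc(Oc3ccc(Nc4nn(C)cc4C(=O)NCC4CCCCC4)cc3)c2cc1C(N)=O` carries cyclohexylmethyl on the amide-type nitrogen. In a functional assay on BaF3 cells (Mus musculus) for antiproliferative activity, read by CCK-8 assay and cell counting, with a stated time of 76 h (a lower number here means a stronger inhibitor, a higher number a weaker inhibitor), compound 1 returns only a limit, > 10000 nM, which is a limit and not a number (the limit of > 10000 nM in this assay, at which 1 of the 3 values shown sits). Compound 2 `COc1cc2nccc(Oc3ccc(Nc4nn(C)cc4C(=O)Nc4cccc(F)c4)cc3)c2cc1C(N)=O` gives 4480 nM in this assay, and compound 3 `COc1cc2nccc(Oc3ccc(Nc4nn(C)cc4C(=O)Nc4ccc(F)cc4)cc3)c2cc1C(N)=O` gives 3060 nM. Of the two numbers shown, that of compound 2 is the higher, but a 1.5-fold lower number from compound 2 to compound 3 (0.17 log units; within the scatter) lies within the scatter, so the two are not distinguished. The measured steps read an at least 2.2-fold lower number from compound 1 to compound 2 (0.34 log units; beyond the scatter) and an at least 3.2-fold lower number from compound 1 to compound 3 (0.51 log units; beyond the scatter), both leaving a limit behind.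

Compound 4 `COc1cc2nccc(Oc3ccc(Nc4nn(C)cc4C(=O)NC4CCCCCCC4)cc3)c2cc1C(N)=O` is not yet measured. Its change from compound 2: cyclooctyl in place of 3-fluorophenyl on an amide-type nitrogen. The step that bears on it is an at least 2.2-fold lower number from compound 1 to compound 2 (0.34 log units; beyond the scatter) run backwards, where a fluorophenyl took the place of cyclohexylmethyl and the number fell out of a limit; here cyclooctyl takes the place of the 3-fluorophenyl, so the expected step in this assay is towards a higher number, of at least modest size, its full extent uncertain because compound 1 sits at the limit (the limit of > 10000 nM in this assay, at which 1 of the 3 values shown sits). Compound 4 is therefore expected near 9000 nM, between 3500 nM and 25000 nM, an expected step of a 2.0-fold higher number from compound 2 to compound 4 (0.30 log units; within the scatter), with a real chance that only a limit is returned.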

Compound 4, half-maximal inhibitory concentration: 3210 nM
Beside the measured number, compound 4's estimate is 2.8-fold (0.45 log units) above it; the whole stated range lies above it.
By their numbers in this assay, from the lowest: compounds 3, 4 and 2 (each within the scatter of the next). At a limit, above all of these: compound 1.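

In this assay, a measurable number on the amide-type nitrogen does not depend on an aromatic ring: with cyclooctyl, one eight-membered non-aromatic ring of carbon only, the readings are a 1.4-fold lower number from compound 2 to compound 4 (0.14 log units; within the scatter) and a 1.0-fold higher number from compound 3 to compound 4 (0.02 log units; within the scatter), so the fluorophenyl groups and cyclooctyl are not distinguished at this position. The earlier gap between cyclohexylmethyl and the fluorophenyl groups therefore cannot be read as a plain split between non-aromatic and aromatic rings, as two non-aromatic carbon rings now also differ: an at least 3.1-fold lower number from compound 1 to compound 4 (0.49 log units; beyond the scatter). Compound 1 returns a limit and not a number, so that step gives no full size: the limit of > 10000 nM in this assay, at which 1 of the 4 values shown sits.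

From the compounds shown here alone, whether the gap between cyclohexylmethyl and cyclooctyl follows from the methyl link or from the ring size stays open, and cyclohexyl set directly on the nitrogen would be the group to separate the two. Going by these compounds, how a ring carrying an amine or a carboxylic acid would read at this position also stays open.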